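Working notes on the series: the step to compound 3

This account rests on a few compounds, and the source may have more. Where it says the series, first, only, none or still open, it means among the compounds named here.

Measured so far:
compound 1 `CC(C)C(c1nnc[nH]1)c1ccc(-c2ccc3cccc(F)c3c2)[nH]c1=O`: 21 nM
compound 2 `CC(C)C(/C=C1/CCNC1=O)c1ccc(-c2ccc3cccc(F)c3c2)[nH]c1=O`: 8.1 nM

In a functional assay on CHO cells for antagonist activity at prostaglandin E2 receptor EP3 subtype (Homo sapiens), read by cAMP accumulation (a lower number here means a stronger inhibitor, a higher number a weaker inhibitor), compound 1 gives 21 nM and compound 2 gives 8.1 nM; compound 2 thus holds the lowest of the two numbers, with compound 1 nearest. Compound 3 `CC(C)C(c1cnc(N)s1)c1ccc(-c2ccc3cccc(F)c3c2)[nH]c1=O` differs from compound 2 by a group of 6 heavy atoms (3 carbon, 2 nitrogen, 1 sulfur; one five-membered aromatic ring with 2 hetero atoms) in place of a group of 7 heavy atoms (5 carbon, 1 nitrogen, 1 oxygen; one five-membered non-aromatic ring with 1 hetero atom), on a saturated chain carbon bound to an aromatic carbon and a saturated chain carbon. Within the data shown here, the one measured step bearing on this is a 2.6-fold lower number from compound 1 to compound 2 (0.41 log units; beyond the scatter), in which a five-membered aromatic ring with 3 hetero atoms gave way to the non-aromatic ring that now leaves. Since compound 3 brings back a five-membered aromatic ring on that carbon, the expected step is a rise, a 2.2-fold higher number from compound 2 to compound 3 (0.35 log units; beyond the scatter). Compound 3 is estimated at 18 nM, between 6 nM and 55 nM.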

Compound 3, half-maximal inhibitory concentration: 39 nM
For compound 3 the middle estimate is 2.2-fold (0.34 log units) below the measured one; the range from low to high includes it.
By their numbers in this assay, from the lowest: compound 2; then compounds 1 and 3 (each within the scatter of the next).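

Working from this saturated chain carbon, 2-amino-1,3-thiazol-5-yl in place of the five-membered non-aromatic ring gives a 4.8-fold higher number from compound 2 to compound 3 (0.68 log units; beyond the scatter) in this assay, so compound 2 keeps the lowest number against both compounds carrying a five-membered aromatic ring. Exchanging one aromatic ring for the other, 2-amino-1,3-thiazol-5-yl in place of 4H-1,2,4-triazol-3-yl, gives a 1.9-fold higher number from compound 1 to compound 3 (0.27 log units; within the scatter), so these two rings are not told apart here. Nothing measured here accounts for these steps.

Going by these compounds, whether an open-chain amide or a carboxylic acid on this carbon would match compound 2 stays open. So does the reading for a six-membered ring such as pyridine.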